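Series notes: phenyl substitution, compound 1 to compound 3

The source may hold more compounds than are shown below. What is called first, only, known or untested is meant among the compounds shown, and "the series" means these compounds.

Compound 1 `CCOC(=O)/C(=C/c1c[nH]c2ccccc12)C(=O)c1ccccc1` is the parent of the series. In a functional assay on MT4 cells (Homo sapiens) for antiproliferative activity, read by MTT assay, with a stated time of 96 h (on this read-out lower numbers stand for an effect already at smaller amounts and higher numbers for an effect only at larger amounts of compound), compound 1 returns only the assay limit, > 100000 nM, so no number places it within the series. Compound 2 `CCOC(=O)/C(=C/c1c[nH]c2ccccc12)C(=O)c1ccc([N+](=O)[O-])cc1` carries a nitro in place of hydrogen on an aromatic carbon; in this assay compound 2 gives 100000 nM. The step of a number no higher from compound 1 to compound 2 (the limit leaves the size open) cannot be sized because the limit of > 100000 nM in this assay, at which 1 of the 2 values shown sits, fixes only one end of it. Compound 3 `CCOC(=O)/C(=C/c1c(-c2ccccc2)[nH]c2ccccc12)C(=O)c1ccccc1` differs from compound 1 by phenyl in place of hydrogen on an aromatic carbon. Among the measured compounds shown here, no measured step covers a phenyl entering this position, and the one step that exists starts from a limit, so it gives no scale for the change. Without such a scale the step of a number no higher from compound 1 to compound 3 (the limit leaves the size open) is expected to stay within the scatter. Compound 3 is expected most likely to reach only the assay limit again. Compound 3 is estimated at 100000 nM, within 20000 nM to 300000 nM.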

Compound 3, half-maximal effective concentration: 7000 nM
Beside the measured number, compound 3's estimate is 14-fold (1.15 log units) above it, outside the stated range (below it).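

In this assay, phenyl in place of hydrogen gives an at least 14-fold lower number from compound 1 to compound 3 (1.15 log units; beyond the scatter), so this position, on the five-membered aromatic ring next to the ring nitrogen, is one where a single change moves the read-out beyond the scatter. Among the compounds shown here, compound 3 is also the first compound with a value clear of the upper end of the range, which gives later changes at this position a usable reference. The size of this step is only a minimum: the limit of > 100000 nM in this assay, at which 1 of the 3 values shown sits.

On these data alone, it remains open whether an aromatic ring is needed at this position, or whether a methyl, a longer chain or an amine would produce a similar shift. As far as these compounds go, it is also open how a carboxylic acid or an amine on the added phenyl would alter the value of compound 3.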